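The source may hold more compounds than are shown below. What is called first, only, known or untested is meant among the compounds shown, and "the series" means these compounds.

Of the compounds shown here, two have been measured in a functional assay on DU-145 cells (Homo sapiens) for inhibition, read by trypan blue exclusion, with a stated time of 96 h; on this read-out higher numbers stand for weaker inhibition of growth and lower numbers for stronger inhibition of growth. Compound 1 `O=C(/C(=C\c1ccc(O)cc1)SCc1ccc(Cl)cc1)c1ccc(Br)cc1` gives 10000 nM, and compound 2 `Cc1ccc(S/C(=C/c2ccc(Cl)cc2)C(=O)c2ccc(Br)cc2)cc1` gives 10000 nM, so compound 2 stands level with compound 1, within the scatter. Compound 3 `O=C(/C(=C\c1ccc(Cl)cc1)SCc1ccc(Cl)cc1)c1ccc(Br)cc1` has not yet been measured. It departs from compound 2 on a sulfur whose other neighbours are a double-bonded chain carbon, with 4-chlorobenzyl in place of 4-methylphenyl on a sulfur. Among the measured compounds shown here, no step between measured compounds is available to gauge this swap, so the main guide is compound 2 at 10000 nM. No change beyond the scatter is expected in this assay, and so no firm direction either. The estimated step, a 1.4-fold lower number from compound 2 to compound 3 (0.15 log units; within the scatter), is therefore small. Compound 3 is expected to give 7000 nM, with an estimated range of 2500 nM to 15000 nM.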

Compound 3, concentration for 50% growth inhibition: 10000 nM
Compound 3: the middle estimate sits 1.4-fold (0.15 log units) below what was measured; the measured number falls inside the stated range.
By their numbers in this assay, from the lowest: compounds 1, 2 and 3 (each within the scatter of the next).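

In this assay, among the compounds shown here, putting 4-chlorobenzyl in place of 4-methylphenyl on a sulfur whose other neighbours are a double-bonded chain carbon gives no change at the digits printed from compound 2 to compound 3 (within the scatter), the first step that can be read at this position. Chloro in place of hydroxy on an aromatic carbon gives no change at the digits printed from compound 1 to compound 3 (within the scatter), so neither of these two single changes moves the number beyond the scatter. No measurement bears on why these steps are flat.

From the compounds shown here alone, whether a longer chain on the sulfur, or an amine or a carboxylic acid in place of the chloro on an aromatic carbon, would move the number remains open. Going by these compounds, the three compounds also share the rest of the core, so the effect of changes elsewhere remains open too.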